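The source may hold more compounds than are shown below. What is called first, only, known or untested is meant among the compounds shown, and "the series" means these compounds.

In a functional assay on NCI-H460 cells (Homo sapiens) for cytotoxicity (a lower number here means a stronger inhibitor, a higher number a weaker inhibitor), compound 1 `COc1ccc(S(=O)(=O)N2CCc3cccc(NC(=O)c4ccc(F)cc4)c32)cc1` gives 95 nM. Compound 2 `COc1ccc(S(=O)(=O)N2CCc3cccc(NCc4ccccc4)c32)cc1` gives > 10000 nM, which is a limit of the assay and not a number. Compound 3 `COc1ccc(S(=O)(=O)N2CCc3cccc(NC(=O)c4ccco4)c32)cc1` differs from compound 2 as follows: (furan-2-yl)carbonyl in place of benzyl on a nitrogen on an aromatic ring. In words, (furan-2-yl)carbonyl stands in place of benzyl on a nitrogen on an aromatic ring, so compound 3 carries a carbonyl there, as compound 1 does. Among the measured compounds shown here, only one measured step bears on this change: an at least 100-fold higher number from compound 1 to compound 2 (2.02 log units; beyond the scatter). That step is large and beyond the scatter, and it replaced (4-fluorophenyl)carbonyl with benzyl at the same place. The change to compound 3 runs the other way, with a different ring on the carbonyl, so a large move to a lower number is expected. The expected step is an at least 83-fold lower number from compound 2 to compound 3 (1.92 log units; beyond the scatter). For compound 3 the estimate is 120 nM, with an expected range from 25 nM to 600 nM.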

Compound 3, half-maximal inhibitory concentration: 9.8 nM
Estimate against measurement, compound 3: 12-fold (1.09 log units) above, and the stated range ends above it.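

In this assay, a second carbonyl compound with a different ring also lies far from the benzyl compound, which gives an at least 1000-fold lower number from compound 2 to compound 3 (3.00 log units; beyond the scatter), so the loss seen with benzyl is not tied to the single (4-fluorophenyl)carbonyl group. The size of this step is only a bound, since one end of it is a limit of the assay and not a number: the limit of > 10000 nM in this assay, at which 1 of the 3 values shown sits.

The ring on the carbonyl also counts, as furan-2-yl in place of 4-fluorophenyl gives a 9.7-fold lower number from compound 1 to compound 3 (0.99 log units; beyond the scatter), a modest step but beyond the scatter.

That step changes the ring and removes the fluorine together, so the compounds shown do not separate the two; a plain phenyl or a thiophen-2-yl on the carbonyl would bear on this. As far as these compounds go, how an acetyl or a methanesulfonyl group on this nitrogen would compare also remains open.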